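The source may hold more compounds than are shown below. What is called first, only, known or untested is meant among the compounds shown, and "the series" means these compounds.

Two compounds of one series have been run in a functional assay on BGC-823 cells (Homo sapiens) for cytotoxicity, read by CCK-8 assay, with a stated time of 24 h (on this read-out higher numbers stand for weaker inhibition and lower numbers for stronger inhibition), so far. Compound 1, with the structure `C/C(=C\c1cc(-c2ccc(C(F)(F)F)cc2)cs1)C(N)=O`, sits at a limit of the assay: in this assay compound 1 gives > 50000 nM, which is a limit and not a number. Compound 2, with the structure `C/C(=C\c1cc(-c2ccc(Cl)cc2)cs1)C(N)=O`, also sits at a limit: in this assay compound 2 gives > 50000 nM, again a limit and not a number. The step that the two limits leave unreadable from compound 1 to compound 2 is therefore of unreadable size, and the only summary available is the limit of > 50000 nM in this assay, at which 2 of the 2 values shown sit. Compound 2 thus stands at the limit, with no number beneath it.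

Compound 3, with the structure `COc1ccc(-c2csc(/C=C(\C)C(N)=O)c2)cc1`, differs from compound 2 by methoxy in place of chloro on an aromatic carbon. Going by the values given here, no measured step bears readably on this change, because the step that the two limits leave unreadable from compound 1 to compound 2 is hidden by two limits, and the only guide is the limit of > 50000 nM in this assay, at which 2 of the 2 values shown sit. On that basis no step beyond the scatter is expected from compound 2 to compound 3, and a step that the limit leaves unreadable from compound 2 to compound 3 is the estimated step. For compound 3 in this assay the expected value is 60000 nM, within a range from 20000 nM to 200000 nM, most likely again reported only as a limit.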

Compound 3, half-maximal inhibitory concentration: > 50000 nM
Compound 3: only a limit was reported (the forecaster's own chance of this, stated with the estimate: 85%); the middle value is on the limit's open side.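

In this assay compound 3 gives > 50000 nM, which is a limit and not a number. The steps to compound 3 from compound 1 and from compound 2 therefore cannot be read. The compounds shown leave open how trifluoromethyl, chloro and methoxy compare, and whether any group in that place would give a number: the limit of > 50000 nM in this assay, at which 3 of the 3 values shown sit.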